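Extending the Sulfur-Bearing Chain of Compound 2

The source may report more compounds than this note shows. Statements on the series, on what has been measured and on what is new or still open speak of the compounds shown alone.

Measured compounds:
compound 1, `C=CCCCCN=C=S`, 1040 nM
compound 2, `CSCCCCCN=C=S`, 500 nM

Going by the values given here, in an assay on TREx-HEK cells for activation of transient receptor potential cation channel subfamily A member 1 (Homo sapiens), read by calcium flux (on this read-out lower numbers stand for an effect already at smaller amounts and higher numbers for an effect only at larger amounts of compound), compound 2 gives 500 nM, the lowest of the two numbers so far; the nearest is compound 1 with 1040 nM, and the step of a 2.1-fold lower number from compound 1 to compound 2 (0.32 log units; beyond the scatter) lies beyond the scatter. The unmeasured compound 3, `CSCCCCCCCN=C=S`, differs from compound 2 as follows: 2-(methylsulfanyl)ethyl in place of methylsulfanyl on a saturated chain carbon, five bonds along the chain from an amide-type nitrogen. Among the compounds with values here, the change is a lengthening of the chain on the sulfur side rather than an exchange of one terminal group for another, so the only measured step, a 2.1-fold lower number from compound 1 to compound 2 (0.32 log units; beyond the scatter), bears on it at most loosely: it shows that the end of this chain can be altered with only a modest shift in this assay. Nothing measured here speaks directly to chain length. A step no larger than the scatter is therefore expected for a 1.3-fold lower number from compound 2 to compound 3 (0.10 log units; within the scatter), with a lower number thought slightly more likely than a higher one. Compound 3 is estimated at 400 nM in this assay, within a range of 150 nM to 1200 nM.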

Compound 3, half-maximal effective concentration: 610 nM
Estimate against measurement, compound 3: 1.5-fold (0.18 log units) below; low and high end bracket the measured number.
By their numbers in this assay, from the lowest: compounds 2, 3 and 1 (each within the scatter of the next, the first and the last beyond it).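

In this assay, 2-(methylsulfanyl)ethyl in place of methylsulfanyl on a saturated chain carbon, five bonds along the chain from an amide-type nitrogen, gives a 1.2-fold higher number from compound 2 to compound 3 (0.09 log units; within the scatter), so this position accepts the longer sulfur-bearing chain with no shift that can be told from the scatter. The earlier step, a 2.1-fold lower number from compound 1 to compound 2 (0.32 log units; beyond the scatter), exchanged the group at the end of the chain and lay beyond the scatter, whereas this change keeps the methylsulfanyl end and leaves a difference that this read-out cannot resolve for this pair. No supporting data are available to account for how closely these two numbers agree.

Two chain lengths carrying the same sulfur end cannot show whether the number would stay level with a still longer chain or would eventually move beyond the scatter. As far as these compounds go, it also remains open whether an amine or a carboxylic acid at the end of the chain, in place of the methylsulfanyl group, would be accepted as readily at this position in this assay.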